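The compounds below may be only part of what the source reports. "The series", "measured", "known", "first", "only" and "open" are said of these compounds alone.

Working notes on the step from compound 1 to compound 4.

Compound 1 (`CC1(C)[C@H]2CC[C@]1(C)C(NC(=O)Nc1ccccc1F)C2`) gives 225000 nM in a physicochemical assay for solubility, in phosphate buffer, at pH 7.4 (a higher number here means a more soluble compound, a lower number a less soluble compound), and stands highest of the three measured compounds. Compound 2 (`O=C(NCCCCNC(=O)NC1CC2CCC1C2)NC1CC2CCC1C2`) gives 75000 nM and compound 3 (`O=C(NCCCCCCCCNC(=O)NCc1ccco1)NCc1ccco1`) gives 50000 nM on the same read-out. Both numbers lie lower than that of compound 1, beyond the usual scatter. For the measured compounds named here, neither compound 2 nor compound 3 shares the core of compound 1, and no measured pair differs in one place, so the series offers no measured step as a guide.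

Compound 4 (`CC1(C)C2CCC1(C)C(NC(=O)Nc1ccccc1F)C2`) has not yet been measured. Its difference from compound 1 is as follows: the two compounds have the same atoms and bonds; at least one stereo element is drawn with a configuration in one of them and without one in the other: 2 of 3 stereo elements differ; a stereocentre at a saturated ring carbon is drawn S in compound 1 and without a configuration in compound 4; a stereocentre at a saturated ring carbon is drawn S in compound 1 and without a configuration in compound 4 (the atoms and bonds stay the same, and two stereocentres at saturated ring carbons drawn S in compound 1 are drawn without a configuration in compound 4).

In this assay no step beyond the scatter is expected, in either direction. Going by the values given here, this expectation rests on compound 1 at 225000 nM as the only measured compound with the same atoms and bonds as compound 4. The estimated step of a 1.1-fold lower number from compound 1 to compound 4 (0.05 log units; within the scatter) is expected to stay within the scatter. For compound 4 the estimate is 200000 nM with an expected range from 110000 nM to 350000 nM for the coming measurement.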

Compound 4, solubility: 225000 nM
Beside the measured number, compound 4's estimate is 1.1-fold (0.05 log units) below it, within the range that was stated.
By their numbers in this assay, from the lowest: compounds 3 and 2 (each within the scatter of the next); then compounds 1 and 4 (each within the scatter of the next).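

The series now has its first readable step in this assay, and it reads no change at the digits printed from compound 1 to compound 4 (within the scatter). With atoms and bonds the same, two stereocentres at saturated ring carbons go from drawn S in compound 1 to drawn without a configuration in compound 4, and the read-out does not separate the pair, which compounds 2 and 3, with their different cores, could not show. For this pair, the step therefore speaks only to a difference in how configuration is drawn, and the single structural fact behind it is this: the fact that one of compounds 1 and 4 is drawn with a defined configuration and the other without, at the place where they differ

On these data alone, the drawing of compound 4 does not tell whether it is one stereoisomer or a mixture, so what the opposite configuration at these two stereocentres would give in this assay stays open. For the compounds shown here, also open is how this read-out answers a real change of atoms on the shared core, such as an amine or a carboxylic acid on it, as no step yet reads a change of that kind.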